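The compounds below may be only part of what the source reports. "The series", "measured", "known", "first", "only" and "open" are said of these compounds alone.

Working notes. Compound 3 `CCCCCC(=O)Nc1ccc2c(c1)[C@@H](c1ccccc1)[C@@H](O)[C@](CC)(CCCC)CS2(=O)=O` sits second highest of the three numbers in an assay on cells for inhibition of ileal sodium/bile acid cotransporter (Homo sapiens) (a higher number here means a weaker inhibitor, a lower number a stronger inhibitor), where compound 3 gives 300 nM. Compound 1 `CCCCCCNc1ccc2c(c1)[C@@H](c1ccccc1)[C@@H](O)[C@](CC)(CCCC)CS2(=O)=O` gives 1670 nM and compound 2 `CCCC[C@]1(CC)CS(=O)(=O)c2ccc(N(C)C)cc2[C@@H](c2ccccc2)[C@H]1O` gives 5 nM. Compound 4 `CCCC[C@]1(CC)CS(=O)(=O)c2ccc([N+](C)(C)C)cc2[C@@H](c2ccccc2)[C@H]1O` differs from compound 3 by a group of 4 heavy atoms (3 carbon, 1 nitrogen; no ring) in place of a group of 8 heavy atoms (6 carbon, 1 nitrogen, 1 oxygen; no ring), on an aromatic carbon, a group with net charge +1 and no donors or acceptors. The step of a 60-fold higher number from compound 2 to compound 3 (1.78 log units; beyond the scatter) shows that removing the dimethylamino for the (pentylcarbonyl)amino costs much; the step of a 330-fold lower number from compound 1 to compound 2 (2.52 log units; beyond the scatter) shows the dimethylamino is markedly favored. Compound 4 carries a group close to the dimethylamino of compound 2, so a large drop in number is expected, a 10-fold lower number from compound 3 to compound 4 (1.00 log units; beyond the scatter), though not necessarily to compound 2. Compound 4 is estimated at 30 nM, range 5 nM to 200 nM.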

Compound 4, half-maximal inhibitory concentration: 83 nM
For compound 4 the middle estimate is 2.8-fold (0.44 log units) below the measured one; low and high end bracket the measured number.
By their numbers in this assay, from the lowest: compound 2; then compound 4; then compound 3; then compound 1.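

In this assay, the group with net charge +1 on this aromatic carbon does not match dimethylamino (a 17-fold higher number from compound 2 to compound 4 (1.22 log units; beyond the scatter)), so the two small nitrogen groups are clearly distinguished here. It still gives a lower number than both longer groups, (pentylcarbonyl)amino (a 3.6-fold lower number from compound 3 to compound 4 (0.56 log units; beyond the scatter)) and hexylamino (a 20-fold lower number from compound 1 to compound 4 (1.30 log units; beyond the scatter)), so a net charge at this carbon does not by itself abolish inhibition. No evidence here explains these differences. As far as these compounds go, it remains open whether a primary amine, methylamino or diethylamino would approach or surpass dimethylamino at this carbon.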